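Moving the Chlorine Around the Ring in an Oxadiazole Ketone Series

This account rests on a few compounds, and the source may have more. Where it says the series, first, only, none or still open, it means among the compounds named here.

Compound 1 `O=C(CCc1nnc(-c2ccccc2Cl)o1)c1ccccc1` gives 35.8% in a functional assay on the whole organism (strain Wistar) for inhibition, with Rattus norvegicus as the target, with stated times of 30 min and 3 h, at a dose of 20 mg/kg by the oral route; a lower number here means less inhibition, a higher number more inhibition at the dose given (going by the name of the read-out). Compound 2 `O=C(CCc1nnc(-c2ccc(Cl)cc2)o1)c1ccccc1` gives 81.5% in this assay; the change 4-chlorophenyl in place of 2-chlorophenyl on an aromatic carbon made the step of a number 45.7 percentage points higher from compound 1 to compound 2 (beyond the scatter). Compound 3 `Cc1ccc(C(=O)CCc2nnc(-c3ccccc3Cl)o2)c(C)c1` gives 60.5% in this assay, the step being a number 24.7 percentage points higher from compound 1 to compound 3 (beyond the scatter). Compound 4 `Cc1ccc(C(=O)CCc2nnc(-c3ccc(Cl)cc3)o2)c(C)c1` has not yet been measured in this assay. It differs from compound 3 by 4-chlorophenyl in place of 2-chlorophenyl on an aromatic carbon, the same change, at the same place, as from compound 1 to compound 2; the two cores differ by 2,4-dimethylphenyl in place of phenyl on a carbonyl carbon. Because a number 45.7 percentage points higher from compound 1 to compound 2 (beyond the scatter) was large while compound 3 already stands at 60.5%, a smaller rise in the number is expected. Compound 4 is thus expected to make the step of a number 24.5 percentage points higher from compound 3 to compound 4 (beyond the scatter). For compound 4 the expected value is 85%, likely between 65% and 98%.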

Compound 4, a percentage reported as inhibition, in the whole organism at one dose (the size of the read-out at that dose, not a potency): 72.6%
Estimate against measurement, compound 4: 12.4 percentage points above; low and high end bracket the measured number.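

In this assay the change to 4-chlorophenyl from 2-chlorophenyl gives a number 12.1 percentage points higher from compound 3 to compound 4 (beyond the scatter) on the second core, so the rise recurs, but not at its earlier size: the same change on two cores in this assay, a number 45.7 percentage points higher (beyond the scatter) from compound 1 to compound 2 and a number 12.1 percentage points higher (beyond the scatter) from compound 3 to compound 4, 33.6 percentage points apart, beyond the scatter of two such steps. Read the other way, 2,4-dimethylphenyl in place of phenyl gives a number 8.9 percentage points lower from compound 2 to compound 4 (within the scatter) and not the rise seen with the 2-chlorophenyl group: the same change on two cores in this assay, a number 24.7 percentage points higher (beyond the scatter) from compound 1 to compound 3 and a number 8.9 percentage points lower (within the scatter) from compound 2 to compound 4, 33.6 percentage points apart, beyond the scatter of two such steps. The chlorine change thus kept its direction on these two cores but not its size, and four compounds show neither why nor how it would behave on a further core.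

Still open is how a 3-chlorophenyl group would compare with the two chlorophenyl groups shown. A longer chain in place of the present one is also untested in these compounds.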